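A few compounds are considered here, and "the series" means these few. Any claim that something is new, unique, unknown or untested is made for them only; others in the source may bear on it.

Among the measured compounds shown here, in a functional assay on MCF7 cells (Homo sapiens) for cytotoxicity, read by WST assay, with a stated time of 72 h (on this read-out higher numbers stand for weaker inhibition and lower numbers for stronger inhibition), compound 3 (`O=C1Nc2ccccc2C1(c1ccc(O)cc1)C1CCCCCC1`) gives 247 nM and holds the highest of the three numbers so far. In the same read-out compound 2 (`O=C1Nc2ccccc2C1(c1ccc(O)cc1)c1ccc(F)cc1`) gives 28 nM and compound 1 (`O=C1Nc2c(ccc(F)c2F)C1(c1ccc(O)cc1)c1ccc(F)c(F)c1`) gives 7.8 nM as the lowest number. Compound 4 (`Cc1cccc2c1NC(=O)C2(c1ccc(O)cc1)C1CCCCCC1`) differs from compound 3 as methyl in place of hydrogen on an aromatic carbon. For the measured compounds named here, the only measured single-place step, an 8.8-fold higher number from compound 2 to compound 3 (0.95 log units; beyond the scatter), is modest but beyond the scatter, and it lies on a saturated ring carbon, so it gives no direct size for a change on the aromatic ring. Compound 1 and compound 2 differ in more than one place and offer no single-place reading either. Going by the values given here, no measured compound carries a methyl. With so little to go on, no step beyond the scatter is expected in this assay, and the estimated 1.6-fold lower number from compound 3 to compound 4 (0.22 log units; within the scatter) is small and leans towards a lower number. For compound 4 the estimated value is 150 nM, with an expected range of 50 nM to 450 nM for the measurement.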

Compound 4, half-maximal inhibitory concentration: > 1000 nM
Compound 4: only a limit was reported; the forecaster's own chance of this, stated with the estimate: 3%; middle value at least 6.6-fold (0.82 log units) away from the limit.
By their numbers in this assay, from the lowest: compound 1; then compound 2; then compound 3. At a limit, above all of these: compound 4.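

Working notes on the aromatic ring: in this assay, methyl in place of hydrogen on an aromatic carbon, ortho to a fused ring and meta to a fused ring, gives an at least 4.0-fold higher number from compound 3 to compound 4 (0.60 log units; beyond the scatter), the first single-place reading on this ring in the series. This carbon is therefore not a silent place on the cycloheptyl background, since one added carbon moves the number beyond the scatter. Compound 4 gives > 1000 nM, which is a limit and not a number, so the step has a lower bound but no upper one: the limit of > 1000 nM in this assay, at which 1 of the 4 values shown sits.

As far as these compounds go, whether an amine, a methoxy group or an ethyl chain on this same carbon would move the number in the same way remains open. Also open, from the compounds shown here alone, is whether the methyl step carries over to the core of compound 2, with 4-fluorophenyl in place of cycloheptyl.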